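Swapping the Aryl Group: What to Expect in Mice

The compounds below may be only part of what the source reports. "The series", "measured", "known", "first", "only" and "open" are said of these compounds alone.

Measured compounds:
compound 1 `Cc1ccc(/C=C2\SC(=O)N(Cc3ccc(C)cc3)C2=O)cc1`: 41.7%
compound 2 `COc1ccc(/C=C2\SC(=O)N(Cc3ccc(C)cc3)C2=O)c(OC)c1`: 40%
compound 3 `COc1ccc(/C=C2\SC(=O)N(Cc3ccc(C)cc3)C2=O)cc1`: 37.6%

All three numbers come from a functional assay on the whole organism (plasma) with Mus musculus as the target, with a stated time of 15 days, at a dose of 10 mg/kg by the oral route; a lower number here means a weaker effect, a higher number a stronger effect of the compound at the dose given. Compound 3 sits alongside the other two: the steps of a number 4.1 percentage points lower from compound 1 to compound 3 (within the scatter) and a number 2.4 percentage points lower from compound 2 to compound 3 (within the scatter) are both within the scatter, so the three compounds cannot be told apart on these data.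

Compound 4 `Cc1ccc(CN2C(=O)S/C(=C\c3ccccc3Cl)C2=O)cc1` differs from compound 3 in one place: 2-chlorophenyl in place of 4-methoxyphenyl on a double-bonded chain carbon bound to a double-bonded ring carbon. Among the measured compounds shown here, no measured step involves a 2-chlorophenyl at this place. The two steps that exist changed groups on the same aryl ring and stayed within the scatter, so the expected step of a number 0.4 percentage points higher from compound 3 to compound 4 (within the scatter) is none beyond the scatter. For compound 4 the estimate in this assay is 38%, with a range from 22% to 54%.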

Compound 4, a percentage reported as activity, at one dose (the size of the read-out at that dose, not a potency): 14.8%
For compound 4 the middle estimate is 23.2 percentage points above the measured one, and the stated range ends above it.
By their numbers in this assay, from the lowest: compound 4; then compounds 3, 2 and 1 (each within the scatter of the next).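

In this assay this place on the double-bonded chain carbon turns out to be sensitive to the choice of aryl group: 2-chlorophenyl brings a number 22.8 percentage points lower from compound 3 to compound 4 (beyond the scatter) and a number 26.9 percentage points lower from compound 1 to compound 4 (beyond the scatter) while the earlier changes on the aryl ring stayed within the scatter. The three earlier compounds alone gave no sign of such a drop. Nothing measured here explains it.

The compounds shown cannot separate the effect of the chlorine from that of its place on the ring. From the compounds shown here alone, how a plain phenyl, or an aryl ring carrying an amine or a carboxylic acid, would fare remains open.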